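The source may hold more compounds than are shown below. What is called first, only, known or untested is meant among the compounds shown, and "the series" means these compounds.

Measured so far:
- compound 1 `Cc1cccc(/C=C2/SC(N3CCC[C@H]3C(=O)Nc3ccc4ncnc(Nc5cccc(Cl)c5)c4c3)=NC2=O)n1` gives 4500 nM in a functional assay on HepG2 cells (Homo sapiens) for antiproliferative activity, read by MTT assay; a higher number here means a weaker inhibitor, a lower number a stronger inhibitor
- compound 2 `COc1ccccc1/C=C1/SC(N2CCC[C@H]2C(=O)Nc2ccc3ncnc(Nc4cccc(Cl)c4)c3c2)=NC1=O` gives 22100 nM in this assay

Among the measured compounds shown here, compound 2 stands highest of the two numbers; its nearest neighbour is compound 1, and the only measured step, a 4.9-fold higher number from compound 1 to compound 2 (0.69 log units; beyond the scatter), is a modest one beyond the scatter. Compound 3 `O=C1N=C(N2CCC[C@H]2C(=O)Nc2ccc3ncnc(Nc4cccc(Cl)c4)c3c2)S/C1=C/c1ccc2ccccc2n1` carries the change (quinolin-2-yl in place of 2-methoxyphenyl on a double-bonded chain carbon bound to a double-bonded ring carbon). For the measured compounds named here, the one step that bears on it swapped an aryl group for a ring bearing a nitrogen in the same place and went the other way, so a modest drop in this assay is expected, a 3.7-fold lower number from compound 2 to compound 3 (0.57 log units; beyond the scatter). Compound 3 is therefore estimated at 6000 nM, within the range 2000 nM to 25000 nM.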

Compound 3, half-maximal inhibitory concentration: 22900 nM
The estimate for compound 3 lay 3.8-fold (0.58 log units) below the measured number, within the range that was stated.
By their numbers in this assay, from the lowest: compound 1; then compounds 2 and 3 (each within the scatter of the next).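

In this assay, the place on a double-bonded chain carbon bound to a double-bonded ring carbon shows a 1.0-fold higher number from compound 2 to compound 3 (0.02 log units; within the scatter) for quinolin-2-yl in place of 2-methoxyphenyl, so a ring nitrogen alone does not go with the lower number of compound 1. The step of a 5.1-fold higher number from compound 1 to compound 3 (0.71 log units; beyond the scatter) for quinolin-2-yl in place of 6-methylpyridin-2-yl sets compound 1 apart from both others. No evidence at hand accounts for this result.

From the compounds shown here alone, whether that lower number follows the methyl group or the ring of 6-methylpyridin-2-yl remains open. Going by these compounds, how plain pyridin-2-yl or a phenyl ring carrying an amine would stand at this place also remains open.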